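This account rests on a few compounds, and the source may have more. Where it says the series, first, only, none or still open, it means among the compounds named here.

Measured compounds:
- compound 1, `CCOc1ccc(-c2nc(-c3ccc4ccccc4c3)cs2)cc1`, 4400 nM
- compound 2, `Cc1cccc(-c2nc(-c3ccc4c(c3)CCN4S(C)(=O)=O)cs2)c1`, 8000 nM

Of the compounds shown here, two have been tested so far in an assay on isolated protein for inhibition of dual specificity protein phosphatase 3 (Homo sapiens), read by fluorescence, in the absence of a further agent; on this read-out lower numbers stand for stronger inhibition and higher numbers for weaker inhibition. Compound 1 gives 4400 nM and compound 2 gives 8000 nM. Compound 2 has the larger of the two numbers, but the gap to compound 1 lies within the usual scatter of repeated measurements, so the two compounds cannot be told apart on this read-out. Going by the values given here, no step between compounds that differ in only one place has been measured, so nothing yet shows how a single change on the shared core moves the numbers.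

The next compound, compound 3, `COc1ccccc1-c1nc(-c2ccc3c(c2)CCN3S(C)(=O)=O)cs1`, is built from compound 2 by one change:

2-methoxyphenyl in place of 3-methylphenyl on an aromatic carbon

Among the compounds with values here, with no measured step of this kind to rest on, the expectation for compound 3 in this assay can only be that it stays near compound 2, whose value is 8000 nM, with any shift likely to be no larger than the scatter. The step from compound 2 to compound 3 is estimated as no change at the digits printed from compound 2 to compound 3 (within the scatter). Compound 3 is therefore expected to give about 8000 nM, within a range from 3000 nM to 22000 nM.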

Compound 3, half-maximal inhibitory concentration: 2700 nM
The estimate for compound 3 lay 3.0-fold (0.47 log units) above the measured number; the whole stated range lies above it.
By their numbers in this assay, from the lowest: compounds 3, 1 and 2 (each within the scatter of the next, the first and the last beyond it).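

In this assay, replacing 3-methylphenyl with 2-methoxyphenyl on the aromatic carbon of the five-membered ring that lies next to the ring nitrogen and next to the ring sulfur gives a 3.0-fold lower number from compound 2 to compound 3 (0.47 log units; beyond the scatter) and so a modest step that stands clear of the noise. Going by these compounds alone, this is the first step on this shared core that changes only one place, and it shows that the number responds to what is attached to the phenyl ring at this position. The data offer no measured explanation for the step, which brings one oxygen and one hydrogen-bond acceptor with the entering group.

The kind of substituent and its spot on the phenyl ring change together in this single step, so the compounds shown cannot say which of the two matters, or whether the oxygen plays any part at all. Going by these compounds, it also remains open whether a hydroxyl group, an amine or a longer chain such as propoxy in place of the methoxy group would move the number further down or back up.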